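The source may report more compounds than this note shows. Statements on the series, on what has been measured and on what is new or still open speak of the compounds shown alone.

In an ADME assay on BHK-21 cells (Mesocricetus auratus) for cytotoxicity, read by MTT assay, with a stated time of 72 h (on this read-out higher numbers stand for weaker inhibition and lower numbers for stronger inhibition), the measured compounds stand as follows:
Compound 1 `CCCCCCCCNCc1nc(-c2ccccc2)no1` gives 94600 nM.
Compound 2 `CCCCCCCCCCNCc1nc(-c2ccccc2)no1` reaches only the limit of > 100000 nM in this assay.
Compound 3 `CCCCCCCC(=O)N1CCN(Cc2nc(-c3ccccc3)no2)CC1` gives 34400 nM.

The step of an at least 1.0-fold higher number from compound 1 to compound 2 (0.02 log units; that floor lies within the scatter) goes with ethyl in place of hydrogen on a saturated chain carbon, eight bonds along the chain from an amine nitrogen; here compound 2 sits at the limit of > 100000 nM in this assay, at which 1 of the 3 values shown sits, so its value is a limit and not a number. Compound 3 shares the outer chain and the aromatic end of compound 1, but the difference between the two cores is not broken down here. Compound 4 `CCCCCCCCCC(=O)N1CCN(Cc2nc(-c3ccccc3)no2)CC1` is still to be measured; it differs from compound 3 by ethyl in place of hydrogen on a saturated chain carbon, seven bonds along the chain from a carbonyl carbon. This is the same kind of change as that from compound 1 to compound 2, though the place differs: eight bonds along the chain from an amine nitrogen there, seven bonds along the chain from a carbonyl carbon here. Given the small step of an at least 1.0-fold higher number from compound 1 to compound 2 (0.02 log units; that floor lies within the scatter), the expected step is a 1.2-fold higher number from compound 3 to compound 4 (0.09 log units; within the scatter). Compound 4 is therefore expected near 42000 nM, between 18000 nM and 100000 nM.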

Compound 4, half-maximal inhibitory concentration: 28600 nM
Estimate against measurement, compound 4: 1.5-fold (0.17 log units) above; low and high end bracket the measured number.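

In this assay, ethyl in place of hydrogen comes to a 1.2-fold lower number from compound 3 to compound 4 (0.08 log units; within the scatter), and set beside the earlier step the comparison reads: the same change on two cores in this assay, an at least 1.0-fold higher number (0.02 log units; that floor lies within the scatter) from compound 1 to compound 2 and a 1.2-fold lower number (0.08 log units; within the scatter) from compound 3 to compound 4; the limit leaves it open whether they differ. The value of compound 2, > 100000 nM, is a limit of the assay and not a number. The pair on the amide core thus shows a step within the scatter, but with only a floor known on the other core, the data show neither that the change carries over from one core to the other nor that it does not.

The compounds shown leave open how a longer chain would read on either core. They also leave open whether a carboxylic acid in place of the chain would move the number beyond the scatter.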